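The source may hold more compounds than are shown below. What is called first, only, known or untested is meant among the compounds shown, and "the series" means these compounds.

Compound 1 `CC1=CC[C@@H]([C@@](C)(O)CCCC(C)(C)NC=S)CC1`: > 100000 nM in a functional assay on NCI-H460 cells (Homo sapiens) for cytotoxicity, read by sulforhodamine B assay; a higher number here means that more compound is tolerated, a lower number that less compound is tolerated
Compound 2 `CC1=CC[C@@H]([C@@](C)(O)CCCC(C)(C)NC(=S)NN)CC1`: > 100000 nM in this assay

Compound 2 is known in this assay only as a limit of the assay, not as a number. Compound 1 likewise reaches only a limit there, so the step that the two limits leave unreadable from compound 1 to compound 2 cannot be read. Both measured values sit at the limit of > 100000 nM in this assay, at which 2 of the 2 values shown sit.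

Compound 3 `CC1=CC[C@@H]([C@@](C)(O)CCCC(C)(C)NC(=S)N/N=C\c2ccccc2)CC1` differs from compound 2 by a group of 8 heavy atoms (7 carbon, 1 nitrogen; one six-membered aromatic ring of carbon only) in place of one nitrogen atom, on an amide-type nitrogen. Among the measured compounds shown here, no measured step bears on this change in a readable way: the one step given, from compound 1 to compound 2, is hidden by two limits, and no other pair touches the thiocarbonyl side. The expectation for compound 3 therefore rests only on where compound 2 stands, and it is expected that compound 3 may again sit at or near the limit in this assay, with a wide range. Compound 3 is estimated at 80000 nM, between 15000 nM and 300000 nM. The step this estimate implies, an at least 1.2-fold lower number from compound 2 to compound 3 (0.09 log units; that floor lies within the scatter), is expected to be small.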

Compound 3, concentration lethal to 50% of the cells: > 100000 nM
Compound 3: no number, only a limit; the forecaster's own chance of this, stated with the estimate: 55%; at least 1.2-fold (0.09 log units) between middle value and limit.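

In this assay compound 3 gives > 100000 nM as a limit of the assay and not a number, so the steps from compound 1 and compound 2 to compound 3 cannot be read. The compounds shown leave open whether any change on the thiocarbonyl side alters cytotoxicity at all.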